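The source may hold more compounds than are shown below. What is called first, only, known or untested is meant among the compounds shown, and "the series" means these compounds.

Measured in a functional assay on HL-60 cells (Homo sapiens) for cytotoxicity, read by CCK-8 assay, with a stated time of 72 h; on this read-out higher numbers stand for weaker inhibition and lower numbers for stronger inhibition:
compound 1 `C=CCn1c(=O)/c(=C\c2cccc(Cl)c2Cl)[nH]c(=O)/c1=C\c1ccccc1OC` gives 2000 nM
compound 2 `C=CCn1c(=O)/c(=C\c2ccccc2OC)[nH]c(=O)/c1=C\c1ccccc1OC` gives 15700 nM
compound 3 `C=CCn1c(=O)/c(=C\c2cccc(Br)c2)[nH]c(=O)/c1=C\c1ccccc1OC` gives 5200 nM

Compound 3 sits second highest of the three numbers; compound 1 gives the lower number and compound 2 the higher, both beyond the scatter (a 2.6-fold higher number from compound 1 to compound 3 (0.41 log units; beyond the scatter); a 3.0-fold lower number from compound 2 to compound 3 (0.48 log units; beyond the scatter)).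

Compound 4 `C=CCn1c(=O)/c(=C\c2cccc(Br)c2)[nH]c(=O)/c1=C\c1cccc(Br)c1` has not been measured. It differs from compound 3 by 3-bromophenyl in place of 2-methoxyphenyl on a double-bonded chain carbon bound to an aromatic carbon, so that both double-bonded chain carbons of compound 4 carry 3-bromophenyl. The same exchange, done on the other arylidene, is what separates compound 2 from compound 3, and that step was a 3.0-fold lower number from compound 2 to compound 3 (0.48 log units; beyond the scatter). Compound 1 also shows that 2-methoxyphenyl sits on the weaker side of its pair (a 7.9-fold higher number from compound 1 to compound 2 (0.89 log units; beyond the scatter)). For the measured compounds named here, only one direct precedent exists, so the expectation is a modest step downward in this assay, roughly of the size seen from compound 2 to compound 3, and it is expected as a 2.6-fold lower number from compound 3 to compound 4 (0.41 log units; beyond the scatter). Compound 4 is therefore estimated at 2000 nM, within 700 nM to 6000 nM.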

Compound 4, half-maximal inhibitory concentration: "not active" (no number reported)
The entry for compound 4 holds no number, so the estimate cannot be set against anything.
By their numbers in this assay, from the lowest: compound 1; then compound 3; then compound 2.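

In this assay, for the compounds shown here, compound 4 is entered as not active with no number, so no step from compound 3 to compound 4 can be read. The compounds shown leave open how far compound 4 lies from compound 3 on this read-out. No supporting data bear on this result.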